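Swapping an Ester for a Thioamide on the Side Chain

This account rests on a few compounds, and the source may have more. Where it says the series, first, only, none or still open, it means among the compounds named here.

Three measured compounds share a core with a short side chain ending in a carbonyl or thiocarbonyl group. Compound 1 `N=C(S)CCn1nc(-c2ccccc2)ccc1=S` gives 62.3% in a functional assay on the whole organism (stomach) for inhibition, with Rattus norvegicus as the target, at a dose of 100 mg/kg by the intraduodenal route; a higher number here means more inhibition at the dose given (going by the name of the read-out), a lower number less inhibition. Compound 2 `NC(=O)CCn1nc(-c2ccccc2)ccc1=O` gives -2.8% in this assay, and compound 3 `CCOC(=O)CCn1nc(-c2ccccc2)ccc1=O` gives 6.3%. Among the compounds with values here, compound 3 stands second highest of these three numbers: the one recorded step, a number 9.1 percentage points higher from compound 2 to compound 3 (within the scatter), lies within the scatter, while compound 1 sits beyond the scatter above compound 3.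

Compound 4 `CN(C)C(=S)CCn1nc(-c2ccccc2)ccc1=O` differs from compound 3 by a group of 5 heavy atoms (3 carbon, 1 nitrogen, 1 sulfur; no ring) in place of a group of 5 heavy atoms (3 carbon, 2 oxygen; no ring), on a saturated chain carbon, two bonds along the chain from an aromatic nitrogen. Within the data shown here, only the step of a number 9.1 percentage points higher from compound 2 to compound 3 (within the scatter) touches the same side chain, and it was within the scatter, so it gives no basis for a large step here. Among the measured compounds shown here, compound 1 carries sulfur in its side chain and is the only compound well above compound 3, yet its core also differs, so that comparison is not clean. A modest rise is expected, and compound 4 is estimated to give 20% in this assay, with a range from -5% to 48%. The expected step is a number 13.7 percentage points higher from compound 3 to compound 4 (beyond the scatter).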

Compound 4, a percentage reported as inhibition, in the whole organism at one dose (the size of the read-out at that dose, not a potency): 46%
The estimate for compound 4 lay 26 percentage points below the measured number, within the range that was stated.
By their numbers in this assay, from the lowest: compounds 2 and 3 (each within the scatter of the next); then compound 4; then compound 1.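

At this saturated chain carbon, two bonds along the chain from an aromatic nitrogen, the end of the side chain can strongly change the result in this assay, which the earlier step within the scatter did not show: the sulfur-bearing group in place of ethoxycarbonyl gives a number 39.7 percentage points higher from compound 3 to compound 4 (beyond the scatter), and the same group in place of the smaller group with carbon, nitrogen and oxygen gives a number 48.8 percentage points higher from compound 2 to compound 4 (beyond the scatter). Compounds 2, 3 and 4 share one core, so a large rise here is tied to the side chain alone, without the different core of compound 1. Nothing measured here explains the rise.

From the compounds shown here alone, the new group brings both sulfur and methyl groups on nitrogen, so which of these matters remains open. A dimethylamide, with oxygen in place of sulfur, would separate the two, and whether a longer chain keeps the rise is also unknown.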